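The source may report more compounds than this note shows. Statements on the series, on what has been measured and on what is new or still open speak of the compounds shown alone.

Working notes on the series, read in a functional assay on PC-3 cells (Homo sapiens) for inhibition, read by MTT assay, with stated times of 18 h and 4 h; a higher number here means a weaker inhibitor, a lower number a stronger inhibitor. Compound 3 `CCCCCCCCOP(=O)(O)OCCSC(=S)N1CCN(C)CC1` gives > 100000 nM, which is a limit and not a number. Compound 2 `CCCCCCCCOP(=O)(O)OCCSC(=S)N1CCCCC1` gives > 100000 nM, which is also a limit. Together these two readings make up (the limit of > 100000 nM in this assay, at which 2 of the 3 values shown sit), so compound 3 has no exact place in the series. Among the compounds with values here, compound 1 `CCCCCCCCCCOP(=O)(O)OCCSC(=S)N1CCCCCC1` gives 32900 nM, the only number so far.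

Compound 4 `CCCCCCCCOP(=O)(O)OCCSC(=S)N1CCCCCC1` follows from compound 3 by azepan-1-yl in place of 4-methylpiperazin-1-yl on a thiocarbonyl carbon. Within the data shown here, the only measured step, a step that the two limits leave unreadable from compound 2 to compound 3, offers no size to carry over. Among the measured compounds shown here, compound 1 carries the same azepan-1-yl group on a decyl chain where compound 4 has an octyl chain, and compound 1, at 32900 nM, is the sole guide for that group. A modest shift towards stronger inhibition is therefore expected in this assay, although another reading that stops at the limit remains likely. The expected step is an at least 1.2-fold lower number from compound 3 to compound 4 (0.09 log units; that floor lies within the scatter). For compound 4 the estimate is 80000 nM, with an expected range of 35000 nM to 150000 nM.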

Compound 4, half-maximal inhibitory concentration: 56800 nM
Estimate against measurement, compound 4: 1.4-fold (0.15 log units) above; the measured number falls inside the stated range.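

Within the data shown here, with the octyl chain held, azepan-1-yl on a thiocarbonyl carbon gives the first octyl compound in this assay that reads as a number rather than a limit, and the steps are an at least 1.7-fold lower number from compound 3 to compound 4 (0.24 log units; that floor lies within the scatter) and an at least 1.7-fold lower number from compound 2 to compound 4 (0.24 log units; that floor lies within the scatter). Both are floors only, and the step between the other two octyl compounds cannot be read, because compound 2 and compound 3 each stop at a limit: the limit of > 100000 nM in this assay, at which 2 of the 4 values shown sit. With azepan-1-yl held, the change of chain gives a 1.7-fold higher number from compound 1 to compound 4 (0.24 log units; within the scatter), so the decyl and octyl chains are not told apart here.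

On these data alone, whether piperidin-1-yl would give a number on a decyl chain stays open. So does how a morpholin-4-yl group, an open-chain diethylamino group or a shorter hexyl chain would read in this assay.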